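The source may hold more compounds than are shown below. What is called first, only, known or untested is meant among the compounds shown, and "the series" means these compounds.

In a functional assay on LOX IMVI cells (Homo sapiens) for cytotoxicity, read by MTT assay, with a stated time of 24 h (a lower number here means a stronger inhibitor, a higher number a weaker inhibitor), compound 1 (`COc1cc(-c2nc(-c3ccccc3)[nH]c2-c2ccnc(NCCCNS(=O)(=O)c3ccc(Cl)cc3)n2)ccc1F`) gives 83100 nM, compound 2 (`COc1cc(-c2nc(-c3ccccc3)[nH]c2-c2ccnc(NCCCNS(=O)(=O)c3ccc(F)cc3)n2)ccc1F`) gives 3960 nM and compound 3 (`COc1cc(-c2nc(-c3ccccc3)[nH]c2-c2ccnc(NCCCNS(=O)(=O)c3ccc(F)cc3)n2)ccc1Cl`) gives 4530 nM. Compound 3 therefore sits with compound 2, well under compound 1. Compound 4 (`COc1ccc(S(=O)(=O)NCCCNc2nccc(-c3[nH]c(-c4ccccc4)nc3-c3ccc(Cl)c(OC)c3)n2)cc1`) carries methoxy in place of fluoro on an aromatic carbon, para to a large group: methoxy in place of fluoro on an aromatic carbon. The closest evidence is a halogen swap at that same place, with a 21-fold lower number from compound 1 to compound 2 (1.32 log units; beyond the scatter), a large step showing that this group can matter. The other step, a 1.1-fold higher number from compound 2 to compound 3 (0.06 log units; within the scatter), concerns a different group and stays within the scatter. No methoxy has been measured at this place, so a higher number of moderate, uncertain size is expected. The estimated change is a 2.4-fold higher number from compound 3 to compound 4 (0.39 log units; beyond the scatter). Compound 4 is estimated at 11000 nM, within an expected range of 2500 nM to 60000 nM.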

Compound 4, half-maximal inhibitory concentration: 1800 nM
Compound 4: middle estimate off by 6.1-fold (0.79 log units), on the high side; measured number outside the range, below it.
By their numbers in this assay, from the lowest: compound 4; then compounds 2 and 3 (each within the scatter of the next); then compound 1.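

In this assay, the change from 4-fluorophenyl to 4-methoxyphenyl gives a 2.5-fold lower number from compound 3 to compound 4 (0.40 log units; beyond the scatter), so a group other than a halogen at this place can lower the number, and fluoro is not the lowest-reading group seen here. Alongside a 21-fold lower number from compound 1 to compound 2 (1.32 log units; beyond the scatter), it shows that this place responds to more than the halogen swap, though the two steps start from different compounds. No measurement at hand accounts for the direction of this step. On these data alone, what an amine or a carboxylic acid would do at this place remains open, as does whether the methoxy step would hold in compound 2.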